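The compounds below may be only part of what the source reports. "The series", "measured", "known", "first", "only" and "open" are said of these compounds alone.

Measured compounds:
compound 1 `O=C(NO)c1ccc(Cl)c(NC(=O)c2ccc(-c3ccccc3)cc2)c1` — 160 nM
compound 2 `CSc1ccc(C(=O)NO)cc1NC(=O)c1ccc(-c2ccccc2)cc1` — 1500 nM

In an ADME assay on isolated protein for inhibition of protein deacetylase HDAC6 (Homo sapiens), read by fluorescence, with a stated time of 90 min (on this read-out lower numbers stand for stronger inhibition and higher numbers for weaker inhibition), compound 1 gives the lower of the two numbers shown; compound 2 sits at a higher number, a step that lies beyond the scatter a 9.4-fold higher number from compound 1 to compound 2 (0.97 log units; beyond the scatter). Compound 3 `O=C(NO)c1ccc(Cl)c(NC(=O)c2ccc(-c3ccccc3)cc2Cl)c1` differs from compound 1 by chloro in place of hydrogen on an aromatic carbon. Within the data shown here, the only measured step concerns a different ring and a different exchange, so no step speaks directly to this change. Without a direct precedent, compound 3 is expected to land near compound 1, with a step of about a 1.6-fold higher number from compound 1 to compound 3 (0.19 log units; within the scatter), within the scatter; its estimated value is 250 nM (range 80 nM to 800 nM).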

Compound 3, half-maximal inhibitory concentration: 2400 nM
Beside the measured number, compound 3's estimate is 9.6-fold (0.98 log units) below it; measured number above the stated range.
By their numbers in this assay, from the lowest: compound 1; then compounds 2 and 3 (each within the scatter of the next).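

Adding chloro on the aromatic carbon ortho to a large group and meta to a phenyl group gives a large step in this assay (a 15-fold higher number from compound 1 to compound 3 (1.18 log units; beyond the scatter)). Among these compounds, the earlier step (a 9.4-fold higher number from compound 1 to compound 2 (0.97 log units; beyond the scatter)) concerned an exchange on a different ring, so this is the first sign that the ring carrying the phenyl group also responds, here to a single added heavy atom. The data at hand offer no measured explanation for this step. On these data alone, whether fluoro, methyl or methoxy on this same carbon would behave like chloro stays open, as does the effect of chloro on the other carbons of this ring.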